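A few compounds are considered here, and "the series" means these few. Any claim that something is new, unique, unknown or untested is made for them only; others in the source may bear on it.

Compound 1 `CC1(C)CC(NC(=O)C(C)(C)/C=C/[C@H](NC(=O)OC(C)(C)C)c2ccccc2)CC(C)(C)N1` stands in the middle of three compounds measured in a physicochemical assay for lipophilicity; on this read-out lower numbers stand for lower lipophilicity and higher numbers for higher lipophilicity. In this assay, compound 1 gives 4.2. Compound 2 `CC1(C)CC(NC(=O)C/C=C/[C@H](NC(=O)OC(C)(C)C)c2ccccc2)CC(C)(C)N1` gives 2.9, which is lower than the number for compound 1 by more than the usual scatter of repeated measurements. Compound 3 `CC1(C)CC(NC(=O)C(/C=C/[C@@H](NC(=O)OC(C)(C)C)c2ccc(F)cc2)(Cc2ccc(F)cn2)Cc2ccc(F)cn2)CC(C)(C)N1` gives 5.8, which is higher than the number for compound 1, again by more than that scatter.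

Compound 4 `CC(C)C[C@H](/C=C/C(C)(C)C(=O)NC1CC(C)(C)NC(C)(C)C1)NC(=O)OC(C)(C)C` has not yet been measured. It keeps the core of compound 1 but carries isobutyl in place of phenyl on a saturated chain carbon bound to an amide-type nitrogen and a double-bonded chain carbon. Both groups are built of carbon only, and neither brings a net charge.

Going by the values given here, no two measured compounds differ in one place alone, so there is no direct measurement of a swap like this one. With only the structural change to go on, no step beyond the scatter is expected, in either direction. The expected step, no change at the digits printed from compound 1 to compound 4 (within the scatter), stays within the scatter. The measured numbers run from compound 2 at 2.9 to compound 3 at 5.8, so the range is kept generous. The estimated value for compound 4 is 4.2, with an expected range from 3.7 to 4.7.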

Compound 4, partition coefficient: 4
The estimate for compound 4 lay 0.20 log units above the measured number, and the stated range covers the measured number.
By their numbers in this assay, from the lowest: compound 2; then compounds 4 and 1 (each within the scatter of the next); then compound 3.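

In this assay, going by these compounds alone, isobutyl in place of phenyl on a saturated chain carbon bound to an amide-type nitrogen and a double-bonded chain carbon gives a number 0.20 log units lower from compound 1 to compound 4 (within the scatter), and this is the first comparison in the set in which two compounds differ in one place alone. Within the data shown here, at this position, then, a six-membered aromatic ring of carbon only and a chain with no ring and fewer heavy atoms cannot be told apart on this read-out, something the earlier compounds, which differ from one another in more than one place, could not show. No independent measurement here speaks to why the two groups read alike.

Whether this tolerance reaches beyond groups built of carbon only stays open, since the compounds shown do not tell what an amine or a carboxylic acid would do on this same carbon, or whether a longer chain would still stay within the scatter. They also leave open whether the same swap would read the same way on a compound that differs from compound 1 elsewhere in the structure.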